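The source may report more compounds than this note shows. Statements on the series, on what has been measured and on what is new or still open speak of the compounds shown alone.

Compound 1 `COc1cc2ncnc(N3CCC(CN4CCN(c5ccccc5OC)CC4)C3)c2cc1OC`: in an assay on membranes from CHO-K1 cells for displacement of a labelled ligand from 5-hydroxytryptamine receptor 7 (Homo sapiens), read by scintillation counting (on this read-out higher numbers stand for weaker inhibition and lower numbers for stronger inhibition), compound 1 gives 56.2 nM.
Compound 2 `COc1cc2ncnc(N3CCN(Cc4nc5ccccc5[nH]4)CC3)c2cc1OC`: in this assay compound 2 gives > 1000 nM, a limit of the assay.
Compound 3 `COc1cc2ncnc(N3CCN(Cc4ccc5ccccc5n4)CC3)c2cc1OC`: in this assay compound 3 gives > 1000 nM, a limit of the assay.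

Compound 3 stands at a limit of this assay and not at a number. The neighbouring step that the two limits leave unreadable from compound 2 to compound 3 is unreadable, since both ends sit at the limit of > 1000 nM in this assay, at which 2 of the 3 values shown sit. Compound 4 `COc1cc2ncnc(N3CCN(Cc4cnc5ccccc5n4)CC3)c2cc1OC` differs from compound 3 by quinoxalin-2-yl in place of quinolin-2-yl on a saturated chain carbon bound to an amine nitrogen in a ring. For the measured compounds named here, no measured step bears on this change, and the only step touching compound 3 tells nothing about its size. Going by the values given here, compound 1 alone gives a number in this assay, and compound 4 shares no step with it. Compound 4 is therefore expected to remain around the limit, at an estimate of 2000 nM within 600 nM to 10000 nM. The expected step that the limit leaves unreadable from compound 3 to compound 4 is accordingly near none beyond the scatter.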

Compound 4, inhibition constant: > 1000 nM
Compound 4: no number, only a limit (the forecaster's own chance of this, stated with the estimate: 75%); the middle value is on the limit's open side.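

No step can be read between compound 2, compound 3 and compound 4, because all three sit at a limit and not at a number: the limit of > 1000 nM in this assay, at which 3 of the 4 values shown sit.

On these data alone, their true values remain open, and with them any ranking of the 1H-benzimidazol-2-yl, quinolin-2-yl and quinoxalin-2-yl groups.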